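A Hydroxy Group on the Saturated Ring

This account rests on a few compounds, and the source may have more. Where it says the series, first, only, none or still open, it means among the compounds named here.

Compound 1 `CC1=C(/C=C/C(=O)/C=C/c2cccc([N+](=O)[O-])c2)C(C)(C)CCC1` is the starting point. Going by the values given here, in a functional assay on PC-3 cells (Homo sapiens) for cytotoxicity, read by MTT assay, with a stated time of 72 h (a higher number here means a weaker inhibitor, a lower number a stronger inhibitor), compound 1 gives 10000 nM, the only true number available. The single other result belongs to compound 2 `CC1=C(/C=C/C(=O)/C=C/c2ccc(O)c([N+](=O)[O-])c2)C(C)(C)CCC1`. Compound 2 gives > 50000 nM, which is a limit of this assay and not a number.

Compound 3 `CC1=C(/C=C/C(=O)/C=C/c2cccc([N+](=O)[O-])c2)C(C)(C)CCC1O` keeps the core of compound 1 and makes one change: hydroxy in place of hydrogen on a saturated ring carbon. In words, this is hydroxy in place of hydrogen on a saturated ring carbon. Among the compounds with values here, one measured step bears on it, since it also puts hydroxy in place of hydrogen, though on an aromatic carbon. That step is an at least 5.0-fold higher number from compound 1 to compound 2 (0.69 log units; beyond the scatter), which lies beyond the scatter. It sits at a different place in the molecule, so it offers only a loose guide to direction, and a smaller move towards a higher number is expected in this assay. The estimated step is a 2.0-fold higher number from compound 1 to compound 3 (0.30 log units; within the scatter). For compound 3 the expected value is 20000 nM, with an estimated range of 7000 nM to 50000 nM.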

Compound 3, half-maximal inhibitory concentration: 5800 nM
The estimate for compound 3 lay 3.4-fold (0.54 log units) above the measured number; the measured number lies below the stated range.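

The change to hydroxy on a saturated ring carbon, next to the ring atom that bears a methyl group, comes out as a 1.7-fold lower number from compound 1 to compound 3 (0.24 log units; within the scatter), so in this assay compound 3 cannot be told apart from compound 1. The earlier hydroxy change, made on an aromatic carbon, was an at least 5.0-fold higher number from compound 1 to compound 2 (0.69 log units; beyond the scatter), so across these compounds the same group does not give the same outcome at both places. Compound 2 carries a limit and not a number: the limit of > 50000 nM in this assay, at which 1 of the 3 values shown sits.

The compounds shown hold only hydroxy at this ring carbon, so they do not tell how an amine, a methoxy group or a carboxylic acid would read there. They also leave open how hydroxy would read on the other carbons of the saturated ring, and whether the result for compound 3 would hold with a hydroxy group on the aromatic ring as well.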